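Adding an aromatic fluorine to compound 2: expected potency

A few compounds are considered here, and "the series" means these few. Any claim that something is new, unique, unknown or untested is made for them only; others in the source may bear on it.

Measured in an assay on brain (strain C57BL6) for displacement of a labelled ligand from AP2-associated protein kinase 1 (Mus musculus), read by scintillation counting, with a stated time of 1 h; a higher number here means a weaker inhibitor, a lower number a stronger inhibitor:
- compound 1 `CC(=O)Nc1cc(-c2ccc(OC[C@@](C)(N)CC(C)C)c(F)c2)ccn1`: 0.24 nM
- compound 2 `CC(=O)Nc1cc(-c2ccc(OC[C@@H](N)CC(C)C)c(F)c2)ccn1`: 0.52 nM

Going by the values given here, compound 2 stands highest of these two numbers in this assay; the only step seen, a 2.2-fold higher number from compound 1 to compound 2 (0.34 log units; beyond the scatter), concerns the chain on the oxygen. Compound 3 `CC(=O)Nc1cc(-c2cc(F)c(OC[C@@H](N)CC(C)C)cc2F)ccn1` differs from compound 2 by fluoro in place of hydrogen on an aromatic carbon. Among the compounds with values here, no measured step touches a substituent on this ring, so nothing bears directly on the change; the step from compound 2 to compound 3 in this assay is expected to be none beyond the scatter, a 1.0-fold lower number from compound 2 to compound 3 (0.02 log units; within the scatter). Compound 3 is therefore estimated at 0.5 nM, between 0.2 nM and 1.5 nM.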

Compound 3, inhibition constant: 0.6 nM
Compound 3: middle estimate off by 1.2-fold (0.08 log units), on the low side; low and high end bracket the measured number.
By their numbers in this assay, from the lowest: compound 1; then compounds 2 and 3 (each within the scatter of the next).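

In this assay the fluoro group on this aromatic carbon, ortho to a large group and para to the fluoro group already present, leaves the number within the scatter (a 1.2-fold higher number from compound 2 to compound 3 (0.06 log units; within the scatter)). Going by these compounds alone, this is the first reading of a change on this ring rather than on the chain on the oxygen, and this carbon accepts a fluoro group with no step beyond the scatter. Nothing available accounts for this result. On these data alone, whether a chloro, methyl or methoxy group on this carbon would read the same remains open. So does whether fluoro would read the same alongside the 1-amino-1,3-dimethylbutyl chain of compound 1.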